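This account rests on a few compounds, and the source may have more. Where it says the series, first, only, none or still open, it means among the compounds named here.

Compound 1 `O=C(O)CN1CCC(Oc2ccc([C@H]3CC[C@]4(CC3)OOC3(O4)C4CC5CC(C4)CC3C5)cc2)CC1` opens this account at the bottom of what the assay can report. In an ADME assay on microsomes from liver (Homo sapiens) for metabolic stability, using NADPH, with a stated time of 60 min, in the presence of a further agent that is not named here (on this read-out lower numbers stand for slow clearance and higher numbers for fast clearance), compound 1 gives < 7 mL.min-1.g-1, which is a limit of the assay and not a number. Going by the values given here, compound 2 `O=C(O)COc1ccc([C@H]2CC[C@]3(CC2)OOC2(O3)C3CC4CC2CC(C3)C4(F)F)cc1` supplies the only true number so far, with compound 2 reading 23 mL.min-1.g-1 in this assay. Among the compounds with values here, the two values therefore fix no exact starting point for what follows, and no step between measured compounds is available as a guide.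

Compound 3 `O=C(O)CCCOc1ccc([C@H]2CC[C@]3(CC2)OOC2(O3)C3CC4CC(C3)CC2C4)cc1` keeps the core of compound 1 and changes only the group on an oxygen on an aromatic ring: 3-carboxypropyl in place of 1-(carboxymethyl)piperidin-4-yl on an oxygen on an aromatic ring. The ring-bearing group gives way to an open chain, 3-carboxypropyl. With nothing measured for this change, the expectation rests on little, and compound 2 at 23 mL.min-1.g-1 is the only numerical reference. A move towards faster clearance is expected, and the estimated size of this move is an at least 2.1-fold higher number from compound 1 to compound 3 (0.33 log units; beyond the scatter). A result that stays at the limit cannot be ruled out. For compound 3 the expected value is 15 mL.min-1.g-1, with an estimated range from 7 mL.min-1.g-1 to 35 mL.min-1.g-1.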

Compound 3, intrinsic clearance in microsomes: < 7 mL.min-1.g-1
Compound 3: only a limit was reported (the forecaster's own chance of this, stated with the estimate: 20%); middle value at least 2.1-fold (0.33 log units) away from the limit.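

The step from compound 1 to compound 3 cannot be read, since both compounds stand at a limit of the assay and neither gives a number: the limit of < 7 mL.min-1.g-1 in this assay, at which 2 of the 3 values shown sit. What the compounds shown leave open is how far 3-carboxypropyl in place of 1-(carboxymethyl)piperidin-4-yl changes clearance in this assay.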